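Two measured analogues, one amino variant still pending

The source may hold more compounds than are shown below. What is called first, only, known or untested is meant among the compounds shown, and "the series" means these compounds.

compound 1 `ClCc1cccc(Cn2cnc3c(Cl)ncnc32)c1` 18200 nM
compound 2 `ClCc1ccccc1Cn1cnc2ncnc(Cl)c21` 19100 nM

In a functional assay on PC-3 cells (Homo sapiens) for cytotoxicity, read by sulforhodamine B assay, with a stated time of 48 h (a higher number here means a weaker inhibitor of growth, a lower number a stronger inhibitor of growth), compound 1 gives 18200 nM, and compound 2 gives 19100 nM; the two numbers lie within the scatter of each other, so compound 1 stands together with compound 2 at one level. Compound 3 `Nc1nc(Cl)c2ncn(Cc3cccc(CCl)c3)c2n1` is not yet measured. It differs from compound 1 by amino in place of hydrogen on an aromatic carbon. Within the data shown here, no measured pair in this set shows that change, so nothing here fixes its size; the expectation is a step no larger than the scatter, in no preferred direction. Compound 3 is therefore expected to give 16000 nM, within 5000 nM to 50000 nM. The step of a 1.1-fold lower number from compound 1 to compound 3 (0.06 log units; within the scatter) implied by that is an estimate only.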

Compound 3, concentration for total growth inhibition: 25100 nM
Estimate against measurement, compound 3: 1.6-fold (0.20 log units) below; low and high end bracket the measured number.
By their numbers in this assay, from the lowest: compounds 1, 2 and 3 (each within the scatter of the next).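

Amino in place of hydrogen on an aromatic carbon, between two ring nitrogen atoms, gives the first readable step at this position in this assay: a 1.4-fold higher number from compound 1 to compound 3 (0.14 log units; within the scatter). The position therefore takes this amino group without a change that can be told from the scatter, although one pair cannot define a trend. Nothing on hand gives a reason for this result.

As far as these compounds go, whether a larger group in the same place, such as a dimethylamino or methoxy group, would move the number remains open. So does the size of the same amino step on compound 2.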